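The source may hold more compounds than are shown below. What is called first, only, known or untested is meant among the compounds shown, and "the series" means these compounds.

In a functional assay on MCF7 cells (Homo sapiens) for inhibition, read by MTT assay, with a stated time of 72 h (a lower number here means a stronger inhibitor, a higher number a weaker inhibitor), compound 1 `Fc1ccc(Cn2cc(CSC(=S)N3CCNCC3)nn2)cc1` gives 49900 nM. Compound 2 `Cc1ccc(Cn2cc(CSC(=S)N3CCN(C(=O)OCc4ccccc4)CC3)nn2)cc1` gives 37800 nM in this assay. Compound 3 `S=C(SCc1cn(Cc2ccc(Cl)cc2)nn1)N1CCNCC1` has "not determined" (no result reported) in this assay.

Compound 3 therefore stands nowhere on the numbers shown: both measured compounds sit at a weak level, and nothing places compound 3 above or below them. Compound 4 `Cc1ccc(Cn2cc(CSC(=S)N3CCNCC3)nn2)cc1` differs from compound 3 by methyl in place of chloro on an aromatic carbon. Among the compounds with values here, no measured pair shows this change, so its effect in this assay is unknown; such a swap is expected to move the result little, if at all beyond the scatter, in no set direction. Because compound 2 gives 37800 nM while carrying the same methyl group, compound 4 is expected at a similar weak level, estimated at 45000 nM with a range of 20000 nM to 100000 nM.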

Compound 4, half-maximal inhibitory concentration: 53200 nM
Beside the measured number, compound 4's estimate is 1.2-fold (0.07 log units) below it; the measured number falls inside the stated range.
By their numbers in this assay, from the lowest: compounds 2, 1 and 4 (each within the scatter of the next).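

In this assay, methyl in place of fluoro on the aromatic carbon gives a step (a 1.1-fold higher number from compound 1 to compound 4 (0.03 log units; within the scatter)), so this position shows no clear response to that swap. Hydrogen in place of benzyloxycarbonyl on the ring's amine nitrogen gives a step (a 1.4-fold higher number from compound 2 to compound 4 (0.15 log units; within the scatter)), so removing that large group shows no clear effect either. No measured evidence bears on why these numbers stay level. As far as these compounds go, whether an amine or a carboxylic acid on the aromatic ring would shift the number remains open. So does the effect of a longer chain on that nitrogen.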